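From butoxy to 3-methoxy-3-methylbutoxy on compound 3

The source may report more compounds than this note shows. Statements on the series, on what has been measured and on what is new or still open speak of the compounds shown alone.

In a physicochemical assay for solubility, at pH 6.8 (a lower number here means a less soluble compound, a higher number a more soluble compound), compound 3 (`CCCCOc1cccc(OCc2[nH]c3ccccc3c(=O)c2C)c1`) gives < 1000 nM, which is a limit of the assay and not a number. Compound 4 (`COC(C)(C)CCOc1cccc(OCc2[nH]c3ccccc3c(=O)c2C)c1`) carries 1-methoxy-1-methylethyl in place of ethyl on a saturated chain carbon, two bonds along the chain from an oxygen on an aromatic ring, which turns butoxy into 3-methoxy-3-methylbutoxy: 1-methoxy-1-methylethyl in place of ethyl on a saturated chain carbon, two bonds along the chain from an oxygen on an aromatic ring.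

Among the compounds with values here, only one measured step offers guidance, and it is a weak guide. Compound 1 (`Cc1c(COCCCCOCC2(C)COC2)[nH]c2ccccc2c1=O`) gives >= 100000 nM, which is also a limit. Compound 2 (`Cc1c(COCCCCO)[nH]c2ccccc2c1=O`) gives >= 100000 nM, again a limit. The measured step is a step that the two limits leave unreadable from compound 1 to compound 2, so it offers no size to carry over.

Compounds 1 and 2, whose chains hold oxygen, stand at the limit of >= 100000 nM in this assay, at which 2 of the 3 values shown sit, and on that slender basis a modest rise in this assay is expected. The estimated step is an at least 1.5-fold higher number from compound 3 to compound 4 (0.17 log units; that floor lies within the scatter). For compound 4 the expected value is 1500 nM, within a range of 500 nM to 8000 nM.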

Compound 4, solubility: 2000 nM
The estimate for compound 4 lay 1.3-fold (0.12 log units) below the measured number, and the stated range covers the measured number.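

In this assay, compound 4 gives 2000 nM, the first value shown here that is a number and not a limit. The change on the butoxy chain gives an at least 2.0-fold higher number from compound 3 to compound 4 (0.30 log units; that floor lies within the scatter), so this place can hold the 3-methoxy-3-methylbutoxy group with a readable result, although the floor of the step alone does not clear the scatter. Compound 3 stands at a limit of the assay, which is why the true size of the step stays hidden and only a floor can be given: the limit of < 1000 nM in this assay, at which 1 of the 4 values shown sits.

The compounds shown do not separate the part played by the added oxygen from that of the added carbons, and a plain 3-methylbutoxy chain would speak to that. As far as these compounds go, how an amine or a carboxylic acid on this chain would read in this assay also remains open.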